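The source may report more compounds than this note shows. Statements on the series, on what has been measured and on what is new or still open speak of the compounds shown alone.

Measured compounds:
- compound 1, `O=C(O)c1csc(-n2nc(-c3ccccc3)c3ccc(F)cc32)n1`, 2 nM in an assay on isolated protein for antagonist activity at prostaglandin E2 receptor EP1 subtype (Homo sapiens), read by reporter gene assay; on this read-out lower numbers stand for stronger inhibition and higher numbers for weaker inhibition
- compound 2, `O=C(O)c1csc(-n2nc(-c3ccc(Cl)cc3)c3ccccc32)n1`, 12 nM in this assay
- compound 3, `O=C(O)c1csc(-n2nc(-c3ccc(C(F)(F)F)cc3)c3ccccc32)n1`, 140 nM in this assay

Among these three numbers compound 2 stands second highest: compound 1 gives a clearly lower number and compound 3 a clearly higher one. Compound 4, `O=C(O)c1csc(-n2nc(-c3ccsc3)c3ccccc32)n1`, is the next compound to be measured, and it differs from compound 2 in one place: thiophen-3-yl in place of 4-chlorophenyl on an aromatic carbon. Among the measured compounds shown here, the only measured step that touches the same group is the one from compound 2 to compound 3, where the chloro was swapped for a trifluoromethyl and the number rose sharply, a 12-fold higher number from compound 2 to compound 3 (1.07 log units; beyond the scatter). That step shows the group in this place matters, but nothing measured tells how a thiophen-3-yl behaves here; the two shown variations are both larger groups on a six-membered ring, while compound 1 carries an unsubstituted phenyl in the same place and a fluoro elsewhere. Taken together, the step from compound 2 to compound 4 is expected to be small, a 1.2-fold lower number from compound 2 to compound 4 (0.08 log units; within the scatter), in either direction, and compound 4 is estimated at 10 nM in this assay, within 3 nM to 40 nM.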

Compound 4, half-maximal inhibitory concentration: 30 nM
Beside the measured number, compound 4's estimate is 3.0-fold (0.48 log units) below it, and the stated range covers the measured number.
By their numbers in this assay, from the lowest: compound 1; then compound 2; then compound 4; then compound 3.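

Replacing the whole 4-chlorophenyl with thiophen-3-yl in this assay gives a 2.5-fold higher number from compound 2 to compound 4 (0.40 log units; beyond the scatter), a step beyond the scatter but smaller than the one produced by changing only the chloro, a 12-fold higher number from compound 2 to compound 3 (1.07 log units; beyond the scatter). This position on the five-membered aromatic ring with 2 nitrogen therefore does not depend on a six-membered ring: a five-membered aromatic ring containing sulfur keeps the number well below that of compound 3. Nothing available explains why compound 4 gives a higher number than compound 2.

As far as these compounds go, how a pyridine ring, a furan ring or a phenyl bearing a methoxy group would behave in this place remains open. Compound 1 differs from compound 2 in more than one place, so the separate contributions of its fluoro and its unsubstituted phenyl also stay unresolved.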